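A few compounds are considered here, and "the series" means these few. Any claim that something is new, unique, unknown or untested is made for them only; others in the source may bear on it.

Working notes on the series. The shared core is seen in compound 1 `CCOC(=O)C1=Cc2ccccc2OC1(OCc1cc(-c2ccc(C)cc2)no1)C(F)(F)F`. In a functional assay on A549 cells (Homo sapiens) for inhibition, read by MTT assay, with a stated time of 24 h (on this read-out higher numbers stand for weaker inhibition and lower numbers for stronger inhibition), compound 1 gives only a limit, > 150000 nM. Compound 2 `CCOC(=O)C1=Cc2ccccc2OC1(OCc1cc(-c2ccc3ccccc3c2)no1)C(F)(F)F` carries naphthalen-2-yl in place of 4-methylphenyl on an aromatic carbon. In this assay compound 2 also gives only a limit, > 150000 nM. The step that the two limits leave unreadable from compound 1 to compound 2 cannot be sized, because of the limit of > 150000 nM in this assay, at which 2 of the 2 values shown sit.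

Compound 3 `Cc1ccc(-c2cc(COC3(C(F)(F)F)Oc4ccccc4C=C3C(=O)O)on2)cc1` differs from compound 1 by hydrogen in place of ethyl on an oxygen next to a carbonyl group. Among the measured compounds shown here, no measured step touches this oxygen, and the single measured step, at the aromatic carbon, left both values at the limit, so neither direction nor size can be drawn from it. Because compound 1 sits at > 150000 nM, compound 3 is expected to remain at the limit as well. The step from this change is expected to be a number no higher from compound 1 to compound 3 (the limit leaves the size open). The estimate for compound 3 in this assay is 150000 nM, within 50000 nM to 400000 nM.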

Compound 3, half-maximal inhibitory concentration: 51200 nM
Estimate against measurement, compound 3: 2.9-fold (0.47 log units) above; measured number inside the range.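

Among the compounds shown here, at the oxygen next to a carbonyl group, hydrogen in place of ethyl is the first change to give a readable direction in this assay: an at least 2.9-fold lower number from compound 1 to compound 3 (0.46 log units; beyond the scatter). Carboxy in place of ethoxycarbonyl therefore brings compound 3 to a number, whereas the earlier change at the aromatic carbon left both compounds at the limit. The step has only a minimum size, because its starting point is one of the limits: the limit of > 150000 nM in this assay, at which 2 of the 3 values shown sit.

From the compounds shown here alone, it remains open whether the lower number depends on the carboxy group itself or only on the loss of ethyl; a methyl ester, a primary amide or a hydroxamic acid at this place would separate the two. Going by these compounds, it also remains open whether carboxy reads the same alongside naphthalen-2-yl in place of 4-methylphenyl.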